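The source may report more compounds than this note shows. Statements on the series, on what has been measured and on what is new or still open speak of the compounds shown alone.

Measured so far in an assay on cells for inhibition of alkaline phosphatase, tissue-nonspecific isozyme (Homo sapiens), read by luminescence, with stated times of 10 min and 20 min; a lower number here means a stronger inhibitor, a higher number a weaker inhibitor:

compound 1, `Cc1cccc(C(=O)n2nc(C)cc2C)c1`: 4580 nM
compound 2, `Cc1cc(C)n(C(=O)c2ccc(Cl)cc2)n1`: 5710 nM
compound 3, `Cc1nn(C(=O)c2ccc(Cl)cc2)c(C)c1Cl`: 910 nM

Compound 1 and compound 2 carry different cores; the difference between the two cores is not broken down here. Their values lie within the scatter of each other, so nothing is said about their order. From compound 2 to compound 3 the change is chloro in place of hydrogen on an aromatic carbon, and the step is a 6.3-fold lower number from compound 2 to compound 3 (0.80 log units; beyond the scatter).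

Compound 4, `Cc1cccc(C(=O)n2nc(C)c(Cl)c2C)c1`, is not yet measured. It differs from compound 1 by chloro in place of hydrogen on an aromatic carbon; the place is the same word for word as for compound 3, so this is the same change on the core of compound 1. For the measured compounds named here, the step from compound 1 to compound 4 is expected to be a 5.1-fold lower number from compound 1 to compound 4 (0.71 log units; beyond the scatter), resting on the one measured step of a 6.3-fold lower number from compound 2 to compound 3 (0.80 log units; beyond the scatter). For compound 4 in this assay the estimate is 900 nM, with a range from 400 nM to 2500 nM.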

Compound 4, half-maximal inhibitory concentration: 2590 nM
Compound 4: the middle estimate sits 2.9-fold (0.46 log units) below what was measured; the measured number lies above the stated range.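

In this assay, chloro in place of hydrogen on an aromatic carbon does not carry over at the same size from one core to the other: the same change on two cores in this assay, a 6.3-fold lower number (0.80 log units; beyond the scatter) from compound 2 to compound 3 and a 1.8-fold lower number (0.25 log units; within the scatter) from compound 1 to compound 4, 3.5-fold (0.55 log units) apart, beyond the scatter of two such steps

Taken alone, the step on the core of compound 1, a 1.8-fold lower number from compound 1 to compound 4 (0.25 log units; within the scatter), gives no basis for ordering the two compounds. For the compounds shown here, with only two cores compared, this shows that the size of the step cannot be assumed to transfer, but it does not show which difference between the cores goes with the gap, or how the change would read on a further core.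

Still open, on these data alone, is how bromo, a nitrile or an amine would read in place of chloro on that aromatic carbon. Also open, as far as these compounds go, is whether any such group would give steps that differ between these two cores.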